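Pyridin-2-yl in Place of Pyridin-4-yl on the Oxygen

This account rests on a few compounds, and the source may have more. Where it says the series, first, only, none or still open, it means among the compounds named here.

Compound 2 `O=S1(=O)c2ccccc2CN1c1cc(F)cc(Oc2ccncc2)c1` was tested in a functional assay on Flp-In T-REx293 cells for antagonist activity at Free fatty acid receptor 1 (Homo sapiens), read by calcium flux; a higher number here means a weaker inhibitor, a lower number a stronger inhibitor. In this assay compound 2 gave > 100000 nM, which is a limit of the assay rather than a measured number. Compound 1 `O=S1(=O)c2ccccc2CN1c1cc(F)cc(Oc2cccnc2)c1` likewise gave the limit > 100000 nM in this assay. The step that the two limits leave unreadable from compound 1 to compound 2 therefore cannot be read, since (the limit of > 100000 nM in this assay, at which 2 of the 2 values shown sit). Compound 3 `O=S1(=O)c2ccccc2CN1c1cc(F)cc(Oc2ccccn2)c1` differs from compound 2 by pyridin-2-yl in place of pyridin-4-yl on an oxygen on an aromatic ring. Going by the values given here, no measured step gives a readable size for such a change, so compound 3 is expected to remain at the limit, an expected step of about a number no higher from compound 2 to compound 3 (the limit leaves the size open). The estimate for compound 3 is 100000 nM, within 30000 nM to 300000 nM.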

Compound 3, half-maximal inhibitory concentration: > 100000 nM
Compound 3: only a limit was reported (the forecaster's own chance of this, stated with the estimate: 80%); the middle value lies on the limit itself.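

The steps among compound 1, compound 2 and compound 3 cannot be read, as all three sit at the same assay limit: the limit of > 100000 nM in this assay, at which 3 of the 3 values shown sit.

Going by these compounds, whether moving the pyridine attachment between these three compounds changes inhibition at all remains open.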